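Taking the isopropyl group off compound 2

The source may hold more compounds than are shown below. What is called first, only, known or untested is meant among the compounds shown, and "the series" means these compounds.

Compound 1 `COc1cccc(NC(=O)c2nnn(Cc3ccc(C#N)cc3)c2N)c1`: 2.5 mL.min-1.g-1
Compound 2 `COc1cccc(NC(=O)c2nnn(Cc3ccc(C(C)C)cc3)c2N)c1`: 3.2 mL.min-1.g-1
Compound 3 `COc1cccc(NC(=O)c2nnn(Cc3ccccc3)c2N)c1`: not yet measured

In an ADME assay on microsomes from liver (Mus musculus, strain CD1) for metabolic stability, read by HPLC, using NADPH, with a stated time of 30 min (on this read-out higher numbers stand for fast clearance and lower numbers for slow clearance), compound 2 gives 3.2 mL.min-1.g-1. Among the compounds with values here, its only measured neighbour is compound 1, with 2.5 mL.min-1.g-1, and the two values lie within the scatter of each other.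

Compound 3 differs from compound 2 by one change, hydrogen in place of isopropyl on an aromatic carbon. Within the data shown here, only one measured step bears on this: a 1.3-fold higher number from compound 1 to compound 2 (0.11 log units; within the scatter), which put isopropyl in place of cyano on an aromatic carbon. Among the measured compounds shown here, that step is small, and no measured compound yet carries hydrogen there. No step beyond the scatter is therefore expected in this assay. The expected step is a 1.1-fold lower number from compound 2 to compound 3 (0.06 log units; within the scatter). Compound 3 is estimated at 2.8 mL.min-1.g-1, with an expected range from 1.4 mL.min-1.g-1 to 5.5 mL.min-1.g-1.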

Compound 3, intrinsic clearance in microsomes: 3.7 mL.min-1.g-1
Beside the measured number, compound 3's estimate is 1.3-fold (0.12 log units) below it, within the range that was stated.
By their numbers in this assay, from the lowest: compounds 1, 2 and 3 (each within the scatter of the next).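

In this assay, the unsubstituted phenyl gives this position a baseline, with a 1.2-fold higher number from compound 2 to compound 3 (0.06 log units; within the scatter) and a 1.5-fold higher number from compound 1 to compound 3 (0.17 log units; within the scatter) as the two steps that reach it. Cyano, isopropyl and hydrogen on this aromatic carbon therefore cannot be told apart on this read-out, so among these three compounds, removing the group altogether does not shift clearance beyond the scatter of repeated measurements. Nothing available explains this flat result.

As far as these compounds go, it remains open whether a group of another kind on the same carbon, such as an amine, a carboxylic acid or a longer alkyl chain, would produce a step beyond the scatter. The compounds shown also say nothing about how changes elsewhere on the shared core, such as at the methoxy group, would affect clearance.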